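Methyl between the ring nitrogens in two cores

A few compounds are considered here, and "the series" means these few. Any claim that something is new, unique, unknown or untested is made for them only; others in the source may bear on it.

Compound 2 `Cc1cncnc1-c1ccccc1` and compound 1 `Cc1ncc(C)c(-c2ccccc2)n1` share one core; compound 3 `c1ncc2c(n1)CCCCCCCCCC2` and compound 4 `Cc1ncc2c(n1)CCCCCCCCCC2` share another, and the difference between the two cores is not broken down here. In a functional assay on the whole organism for inhibition, with Rattus norvegicus as the target, with stated times of 1 h and 3.5 h, at a dose of 100 mg/kg by the oral route (on this read-out higher numbers stand for more inhibition at the one dose given (going by the name of the read-out) and lower numbers for less inhibition), compound 2 gives 48% and compound 1 gives 12%. The change methyl in place of hydrogen on an aromatic carbon is thus a number 36 percentage points lower from compound 2 to compound 1 (beyond the scatter). In this assay compound 3 gives < 5%, which is a limit of the assay rather than a number (the limit of < 5% in this assay, at which 1 of the 3 values shown sits). The change methyl in place of hydrogen on an aromatic carbon is the same kind of change, though here the place is part of a fused or bridged system of two rings, meta to a fused ring and para to a fused ring, rather than meta to a group of 6 heavy atoms and para to a methyl group. From compound 3 to compound 4 a step that the limit leaves unreadable from compound 3 to compound 4 is expected. This rests on the fall a number 36 percentage points lower from compound 2 to compound 1 (beyond the scatter) and on compound 3 already sitting at the assay limit. Compound 4 is therefore estimated at 4%, between 0% and 12%, most likely again reported only as a limit.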

Compound 4, a percentage reported as inhibition, in the whole organism at one dose (the size of the read-out at that dose, not a potency): < 5%
Compound 4 was reported as a limit; the forecaster's own chance of this, stated with the estimate: 70%; the middle value lies beyond the limit too.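

Compound 3 and compound 4 are both reported only as limits of the assay, so no step from compound 3 to compound 4 can be read: the limit of < 5% in this assay, at which 2 of the 4 values shown sit.

The compounds shown leave open whether methyl in place of hydrogen changes inhibition in the core of compound 3.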